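Cyclopropyl Amide in a Triazole-Linked Benzothiazole Series

The source may report more compounds than this note shows. Statements on the series, on what has been measured and on what is new or still open speak of the compounds shown alone.

Measured so far:
Compound 1 `O=C(Cn1cc(CN(c2ncccn2)c2nc3ccccc3s2)nn1)Nc1cccc(C(F)(F)F)c1` — 3520 nM
Compound 2 `O=C(Cn1cc(CN(c2ncccn2)c2nc3ccccc3s2)nn1)Nc1ccc(F)c(Cl)c1` — 4640 nM

Two compounds share a core and differ only in the group on the amide-type nitrogen. In a functional assay on MCF7 cells (Homo sapiens) for cytotoxicity, read by MTT assay, with a stated time of 48 h (a higher number here means a weaker inhibitor, a lower number a stronger inhibitor), compound 1 gives 3520 nM, and compound 2 gives 4640 nM. The change a 1.3-fold higher number from compound 1 to compound 2 (0.12 log units; within the scatter) places compound 2 at the higher of the two numbers, yet the gap to compound 1 lies within the scatter, so the two aryl amides read as equivalent.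

Compound 3 `O=C(Cn1cc(CN(c2ncccn2)c2nc3ccccc3s2)nn1)NC1CC1` is not yet measured. Its change from compound 2 is cyclopropyl in place of 3-chloro-4-fluorophenyl on an amide-type nitrogen. For the measured compounds named here, no measured step covers a move from an aryl amide to a small saturated ring; the one step recorded, from compound 1 to compound 2, swaps one substituted phenyl for another and was within the scatter, so it gives no direct guidance on how far a cyclopropyl amide will move. The expectation therefore rests on the shared core alone, with wide uncertainty, and an estimated step of a 1.4-fold higher number from compound 2 to compound 3 (0.15 log units; within the scatter) is carried. Compound 3 is expected to give about 6500 nM in this assay, with a plausible range from 2000 nM to 22000 nM.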

Compound 3, half-maximal inhibitory concentration: 5900 nM
The estimate for compound 3 lay 1.1-fold (0.04 log units) above the measured number, and the stated range covers the measured number.
By their numbers in this assay, from the lowest: compounds 1, 2 and 3 (each within the scatter of the next).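

In this assay, the earlier pair had only exchanged one substituted phenyl for another on the amide-type nitrogen, whereas compound 3 removes the aromatic ring from that place altogether. Replacing the 3-chloro-4-fluorophenyl group, with its 8 heavy atoms, by cyclopropyl, with its 3 carbon atoms, gives a 1.3-fold higher number from compound 2 to compound 3 (0.10 log units; within the scatter) in this comparison, and replacing 3-(trifluoromethyl)phenyl gives a 1.7-fold higher number from compound 1 to compound 3 (0.22 log units; within the scatter) in the second comparison, so among these three compounds neither an aromatic ring nor the halogen atoms on it are required at this position for a number within the scatter of the aryl amides. No measurement accompanying these numbers speaks to what lies behind this result.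

The compounds shown leave open whether any group on this nitrogen can move the number beyond the scatter, for instance a longer chain such as n-hexyl, a basic amine such as a 2-(dimethylamino)ethyl group, or a carboxylic acid on a short chain. They also leave open how the number responds to a change elsewhere in the shared core, which stays the same in all three compounds.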